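The source may report more compounds than this note shows. Statements on the series, on what has been measured and on what is new or still open speak of the compounds shown alone.

Compound 3 `CCN(CC)CCN(C)C(=O)Nc1cc2c(Nc3ccc(F)c(Cl)c3)ncnc2cc1O[C@H]1CCOC1` gives 481 nM in a functional assay on A-431 cells (Homo sapiens) for antiproliferative activity, read by sulforhodamine B assay, with a stated time of 72 h (on this read-out lower numbers stand for stronger inhibition and higher numbers for weaker inhibition), the highest of the three numbers as read, yet the steps of a 1.9-fold higher number from compound 1 to compound 3 (0.29 log units; within the scatter) and a 1.1-fold higher number from compound 2 to compound 3 (0.03 log units; within the scatter) both fall within the scatter, so compound 3 is not separable from compound 2 `CN(C)CCN(C)C(=O)Nc1cc2c(Nc3ccc(F)c(Cl)c3)ncnc2cc1O[C@H]1CCOC1` at 450 nM or compound 1 `O=C(NCCN1CCCC1)Nc1cc2c(Nc3ccc(F)c(Cl)c3)ncnc2cc1O[C@H]1CCOC1` at 247 nM. Compound 4 `O=C(Nc1cc2c(Nc3ccc(F)c(Cl)c3)ncnc2cc1O[C@H]1CCOC1)N1CCC(F)(F)CC1` differs from compound 3 by 4,4-difluoropiperidin-1-yl in place of (2-(diethylamino)ethyl)(methyl)amino on a carbonyl carbon. Within the data shown here, no measured step puts a ring in place of the chain group on the carbonyl carbon; the steps of a 1.8-fold higher number from compound 1 to compound 2 (0.26 log units; within the scatter) and a 1.9-fold higher number from compound 1 to compound 3 (0.29 log units; within the scatter) only show that reshaping that group moved the number little. A small rise is therefore expected, a 1.4-fold higher number from compound 3 to compound 4 (0.13 log units; within the scatter), not clearly beyond the scatter. Compound 4 is estimated at 650 nM, between 200 nM and 2200 nM.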

Compound 4, half-maximal inhibitory concentration: 1860 nM
Estimate against measurement, compound 4: 2.9-fold (0.46 log units) below; the range from low to high includes it.
By their numbers in this assay, from the lowest: compounds 1, 2 and 3 (each within the scatter of the next); then compound 4.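

Among these compounds, earlier reshaping of the group on the carbonyl carbon stayed within the scatter, but 4,4-difluoropiperidin-1-yl is the first change there to go beyond it in this assay: a 3.9-fold higher number from compound 3 to compound 4 (0.59 log units; beyond the scatter), a 4.1-fold higher number from compound 2 to compound 4 (0.62 log units; beyond the scatter) and a 7.5-fold higher number from compound 1 to compound 4 (0.88 log units; beyond the scatter). This position therefore does respond to what it carries, and all three chain groups give lower numbers than this ring. Nothing measured here explains the rise.

The compounds shown leave open whether the ring, its two fluorines or the absence of the chain's terminal amine matters. Piperidin-1-yl and 4-methylpiperazin-1-yl on the same carbonyl carbon would help separate these.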